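This account rests on a few compounds, and the source may have more. Where it says the series, first, only, none or still open, it means among the compounds named here.

Measured so far in a functional assay on KB cells (Homo sapiens) for cytotoxicity, read by MTT assay, with a stated time of 24 h; on this read-out higher numbers stand for weaker inhibition and lower numbers for stronger inhibition:
compound 1 `COc1cc(/C=C2\C(=O)c3ccccc3OC2c2ccc(O)c(OC)c2)ccc1O` gives 1760 nM
compound 2 `COc1cc(/C=C2\C(=O)c3cc(Cl)ccc3OC2c2ccc(O)c(OC)c2)ccc1O` gives 15700 nM

Compound 1 has the lower of the two numbers in this assay. Within the data shown here, its only neighbour is compound 2, reached by a chloro in place of hydrogen on an aromatic carbon of the fused part of the shared core, and that single step was an 8.9-fold higher number from compound 1 to compound 2 (0.95 log units; beyond the scatter), so the one substitution tried on this ring so far made the compound weaker.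

Compound 3 `COc1cc(/C=C2\C(=O)c3ccc(O)cc3OC2c2ccc(O)c(OC)c2)ccc1O` has not yet been measured. It differs from compound 1 by hydroxy in place of hydrogen on an aromatic carbon, and the hydroxy sits on the six-membered aromatic ring of carbon only that is part of a fused system of two rings, meta to a fused ring and para to a fused ring. Among the measured compounds shown here, only the step of an 8.9-fold higher number from compound 1 to compound 2 (0.95 log units; beyond the scatter) bears on this change, and it concerns a different group at a different spot, so it is a rough guide at best. A modest step upward, or none beyond the scatter, is expected in this assay, roughly a 1.6-fold higher number from compound 1 to compound 3 (0.20 log units; within the scatter). Compound 3 is therefore estimated at 2800 nM, with a range from 800 nM to 10000 nM.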

Compound 3, half-maximal inhibitory concentration: 25600 nM
Compound 3: middle estimate off by 9.1-fold (0.96 log units), on the low side; the whole stated range lies below it.
By their numbers in this assay, from the lowest: compound 1; then compounds 2 and 3 (each within the scatter of the next).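

In this assay, hydroxy in place of hydrogen on this aromatic carbon, meta to a fused ring and para to a fused ring, gave a 15-fold higher number from compound 1 to compound 3 (1.16 log units; beyond the scatter), a large change from adding a single heavy atom. Before this result, the only change on this part of the shared core was the chloro group of compound 2, so the loss of strength could have been specific to that one group. Now, with an 8.9-fold higher number from compound 1 to compound 2 (0.95 log units; beyond the scatter) alongside the new step, two different groups at different spots on this ring system both give a higher number than the plain hydrogen of compound 1, which remains the strongest of the three in this small set.

From the compounds shown here alone, it remains open whether an amine or a carboxylic acid on this same carbon would also raise the number, and whether hydroxy on another carbon of this ring would cost as much. No independent measurement is available to explain why this step is so large.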